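Swapping the dimethylamino for fluoro on a shared enone core

This account rests on a few compounds, and the source may have more. Where it says the series, first, only, none or still open, it means among the compounds named here.

Measured compounds:
- compound 1 `COc1cc(/C=C2\CCC/C(=C\c3ccccc3[N+](=O)[O-])C2=O)cc(OC)c1OC`: 1520 nM
- compound 2 `CN(C)c1ccc(/C=C2\CCC/C(=C\c3ccccc3[N+](=O)[O-])C2=O)cc1`: 164000 nM
- compound 3 `COc1cc(/C=C2\CCC/C(=C\c3cccc([N+](=O)[O-])c3)C2=O)cc(OC)c1OC`: 42200 nM

In a functional assay on L1210 cells (Mus musculus) for cytotoxicity, with a stated time of 48 h (on this read-out higher numbers stand for weaker inhibition and lower numbers for stronger inhibition), compound 2 gives the highest of the three numbers, meaning the weakest inhibition of cell growth. Compound 3 sits nearest to it, and compound 1 is furthest away with by far the lowest number. Among the measured compounds shown here, the only single-point step among the measured compounds is a 28-fold higher number from compound 1 to compound 3 (1.44 log units; beyond the scatter), which concerns the nitrophenyl and not the ring changed here, so it does not bear on the present step. Compound 4 `O=C1/C(=C/c2ccc(F)cc2)CCC/C1=C\c1ccccc1[N+](=O)[O-]` arises from compound 2 by fluoro in place of dimethylamino on an aromatic carbon. For the measured compounds named here, no measured step covers this change. Compound 4 is expected to give 15000 nM in this assay, within 3000 nM to 80000 nM, an estimated step of an 11-fold lower number from compound 2 to compound 4 (1.04 log units; beyond the scatter).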

Compound 4, half-maximal inhibitory concentration: 8400 nM
Compound 4: middle estimate off by 1.8-fold (0.25 log units), on the high side; the measured number falls inside the stated range.
By their numbers in this assay, from the lowest: compound 1; then compound 4; then compound 3; then compound 2.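

In this assay, fluoro in place of dimethylamino gives a 20-fold lower number from compound 2 to compound 4 (1.29 log units; beyond the scatter) with the rest of the molecule unchanged. Among the compounds shown here, this is the first measured change on this aromatic ring, and it shows that the group held on this aromatic carbon can move the number strongly while the 2-nitrophenyl side stays fixed. Nothing measured here explains the drop.

The compounds shown leave open how a plain amino group, a hydroxyl or a chlorine would behave at this position. They also leave open whether the same swap gives a step of similar size when the nitro group sits as in compound 3.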